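Swapping 3,5-dimethoxyphenyl for 3-cyanophenyl: an expected outcome

This account rests on a few compounds, and the source may have more. Where it says the series, first, only, none or still open, it means among the compounds named here.

Compound 1 `Cc1nc(-c2ccccc2)c(C(=O)N2CCN(c3cccc(Cl)c3)CC2)o1` in an ADME assay (liver) for metabolic stability, with Liver microsome (Homo sapiens) as the target, read by LC-MS, using microsomes, with a stated time of 1 h, tested at 5 uM (a higher number here means that more of the compound is left, a lower number that less of the compound is left), gives 13.5%
Compound 2 `Cc1nc(-c2ccccc2)c(C(=O)N2CCN(c3cccc(C)c3C)CC2)o1` gives 29.8%
Compound 3 `COc1cc(OC)cc(N2CCN(C(=O)c3oc(C)nc3-c3ccccc3)CC2)c1` gives 15.8%

Compound 3 sits level with compound 1, the step of a number 2.3 percentage points higher from compound 1 to compound 3 (within the scatter) showing no separation between them. It falls clearly short of compound 2, as the step of a number 14 percentage points lower from compound 2 to compound 3 (beyond the scatter) shows. Compound 4 `Cc1nc(-c2ccccc2)c(C(=O)N2CCN(c3cccc(C#N)c3)CC2)o1` carries 3-cyanophenyl in place of 3,5-dimethoxyphenyl on an amine nitrogen in a ring. Going by the values given here, no measured compound carries a nitrile, so the comparison is indirect. Among the compounds with values here, only the 2,3-dimethylphenyl of compound 2 has moved the number so far, through the modest step of a number 16.3 percentage points higher from compound 1 to compound 2 (beyond the scatter). Exchanging 3-chlorophenyl for 3,5-dimethoxyphenyl did not. Compound 1, with its 3-chlorophenyl, is the closest in form to compound 4. Compound 1 stays low, with 13.5%. The expected step, a number 4.2 percentage points higher from compound 3 to compound 4 (within the scatter), is therefore no shift beyond the scatter in this assay, with some allowance upward. The estimate for compound 4 is 20% (expected range 8% to 38%).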

Compound 4, percent of the compound remaining: 8%
Estimate against measurement, compound 4: 12 percentage points above; measured number inside the range.
By their numbers in this assay, from the lowest: compounds 4, 1 and 3 (each within the scatter of the next); then compound 2.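

With a nitrile now at this position, the picture in this assay changes little: a number 5.5 percentage points lower from compound 1 to compound 4 (within the scatter), and a number 7.8 percentage points lower from compound 3 to compound 4 (within the scatter), so 3-cyanophenyl cannot be told apart from 3-chlorophenyl or 3,5-dimethoxyphenyl here. The separation remains with 2,3-dimethylphenyl alone, as a number 21.8 percentage points lower from compound 2 to compound 4 (beyond the scatter), which leaves compound 2 apart from compounds 1, 3 and 4, now with three different groups on the low side of it. Nothing measured here bears on what lies behind this difference.

The compounds shown leave open whether a single methyl group on this phenyl ring would match the 2,3-dimethylphenyl of compound 2, or whether both methyl groups are needed. They also leave open how a fluoro group, a carboxylic acid or an amine on that ring would read in this assay.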